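Chloro for fluoro on a bis-furan amidine scaffold

This account rests on a few compounds, and the source may have more. Where it says the series, first, only, none or still open, it means among the compounds named here.

The measured compounds:
compound 1 `N=C(N)c1ccc(-c2ccc(-c3cncc4ccccc34)s2)s1` — 1270 nM
compound 2 `N=C(N)c1ccc(-c2ccc(-c3ccc(F)cc3)o2)o1` — 1360 nM

In a functional assay on MDA-MB-468 cells (Homo sapiens) for inhibition, read by sulforhodamine B assay, with a stated time of 48 h (on this read-out higher numbers stand for weaker inhibition of growth and lower numbers for stronger inhibition of growth), compound 1 gives 1270 nM and compound 2 gives 1360 nM. Compound 2 carries the higher of the two numbers, but its nearest neighbour, compound 1, lies within the usual scatter of it, so nothing separates the two beyond repeat-to-repeat noise. Within the data shown here, no pair of measured compounds differs in one place, so no measured step is available as a guide.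

Compound 3 `N=C(N)c1ccc(-c2ccc(-c3ccc(Cl)cc3)o2)o1` is not yet measured. It differs from compound 2 by chloro in place of fluoro on an aromatic carbon, on a six-membered aromatic ring of carbon only, para to a large group. With no measured step of this kind in hand, the exchange of one halogen for another at the same position is expected to move this assay little, if at all, perhaps towards a somewhat lower number; the estimated step from compound 2 to compound 3 is a 1.4-fold lower number from compound 2 to compound 3 (0.16 log units; within the scatter). Compound 3 is therefore expected to give about 950 nM, with a likely range from 400 nM to 2500 nM.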

Compound 3, concentration for 50% growth inhibition: 2190 nM
Estimate against measurement, compound 3: 2.3-fold (0.36 log units) below; measured number inside the range.
By their numbers in this assay, from the lowest: compounds 1, 2 and 3 (each within the scatter of the next).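

In this assay, among these compounds, the exchange of chloro in place of fluoro on an aromatic carbon, on a six-membered aromatic ring of carbon only, para to a large group, gives the step of a 1.6-fold higher number from compound 2 to compound 3 (0.21 log units; within the scatter) and provides the first comparison here between compounds that differ in one place. Since this step lies within the scatter, the read-out does not separate the two halogens at this position, and compound 2 and compound 3 cannot be told apart beyond repeat-to-repeat noise. No available evidence bears on this result.

As far as these compounds go, what remains open is whether any other group at this position would separate from the two halogens in this assay, for example a methoxy group, an amine or a carboxylic acid. From the compounds shown here alone, it also remains open whether the same exchange of halogens would read alike on a different core, such as that of compound 1, so this single step cannot be taken as a general statement about halogens on these compounds.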